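Swapping the Ring on the Amide Nitrogen: Limit Expected Again

The source may report more compounds than this note shows. Statements on the series, on what has been measured and on what is new or still open speak of the compounds shown alone.

Compound 1, `O=C(Nc1cccc(C(=O)O)c1O)c1ccc(/C=C2\SC(=S)N(c3ccc([N+](=O)[O-])cc3)C2=O)cc1`, in an assay on isolated protein for inhibition of Apoptosis regulator Bcl-2 (Homo sapiens), read by fluorescence polarization; on this read-out lower numbers stand for stronger inhibition and higher numbers for weaker inhibition: > 10000 nM
Compound 2, `COc1ccc(N2C(=O)/C(=C/c3ccc(OCc4ccc(C(=O)O)cc4)cc3)SC2=S)cc1`, in this assay: > 10000 nM

Compound 2 is known only by a limit of this assay, not by a number, and that limit is > 10000 nM. Compound 1 likewise gives only a limit, > 10000 nM. Both measured compounds therefore stand at the limit of > 10000 nM in this assay, at which 2 of the 2 values shown sit, and nothing in the data separates the two from each other.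

Compound 3 is `O=C(O)c1ccc(COc2ccc(/C=C3\SC(=S)N(c4c(F)cccc4F)C3=O)cc2)cc1`. It is reached from compound 2 by a single change: 2,6-difluorophenyl in place of 4-methoxyphenyl on an amide-type nitrogen in a ring. Among the measured compounds shown here, since no step between measured compounds is available, nothing in the numbers says how a change of this kind shifts the read-out. With compound 2 at its limit, > 10000 nM, the most that can be said is that no shift beyond the usual scatter is expected in this assay, and that the result for compound 3 is more likely to be another limit than a number. Compound 3 is therefore expected to come in near 15000 nM, between 3000 nM and 60000 nM. That estimate amounts to a step that the limit leaves unreadable from compound 2 to compound 3.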

Compound 3, inhibition constant: > 10000 nM
Compound 3: a limit, no number; the forecaster's own chance of this, stated with the estimate: 75%; the middle value does not contradict the limit.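

Compound 3 gives > 10000 nM in this assay as a limit and not a number. Compound 2 is also known only by a limit, so no step can be read from compound 2 to compound 3. The compounds shown leave open how far any change to them would shift the read-out, since all of them stand at one limit: the limit of > 10000 nM in this assay, at which 3 of the 3 values shown sit.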